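Replacing the thiophene of compound 2 with 2-chlorophenyl

This account rests on a few compounds, and the source may have more. Where it says the series, first, only, none or still open, it means among the compounds named here.

Compound 1 `Nc1ncnn2c([C@@H]3O[C@H](CO)[C@@H](O)[C@H]3O)cc(-c3ccoc3)c12` in a functional assay on CAPAN-1 cells (Homo sapiens) for antiproliferative activity, with a stated time of 72 h; on this read-out higher numbers stand for weaker inhibition and lower numbers for stronger inhibition: 900 nM
Compound 2 `Nc1ncnn2c([C@@H]3O[C@H](CO)[C@@H](O)[C@H]3O)cc(-c3ccsc3)c12` in this assay: 56200 nM

Of these two, compound 2 stands highest, at 56200 nM. Compound 3 `Nc1ncnn2c([C@@H]3O[C@H](CO)[C@@H](O)[C@H]3O)cc(-c3ccccc3Cl)c12` carries 2-chlorophenyl in place of thiophen-3-yl on an aromatic carbon. Among the compounds with values here, one measured step bears on this change, a 62-fold higher number from compound 1 to compound 2 (1.80 log units; beyond the scatter), and it is large, so a swap at this place can move the number far. That step does not show which way a 2-chlorophenyl group would go. In this assay, only a step within the scatter is expected, leaning lower. The expected step is a 1.9-fold lower number from compound 2 to compound 3 (0.27 log units; within the scatter). The estimate for compound 3 is 30000 nM, with an expected range of 5000 nM to 100000 nM.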

Compound 3, half-maximal inhibitory concentration: 54900 nM
Beside the measured number, compound 3's estimate is 1.8-fold (0.26 log units) below it, within the range that was stated.
By their numbers in this assay, from the lowest: compound 1; then compounds 3 and 2 (each within the scatter of the next).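

In this assay, 2-chlorophenyl and thiophen-3-yl cannot be told apart on this aromatic carbon, with a 1.0-fold lower number from compound 2 to compound 3 (0.01 log units; within the scatter) as the step. The gap to furan-3-yl recurs with a six-membered aromatic ring of carbon only, as a 61-fold higher number from compound 1 to compound 3 (1.79 log units; beyond the scatter) shows, so compound 1 stands apart from two quite different replacements. Nothing measured here gives a reason for this. Open, going by these compounds, is whether furan-3-yl is unusual among small aromatic rings at this place, and how a plain phenyl without the chlorine or an amine would read.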